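Carbamate in place of carbonate at a nucleoside side chain

The source may report more compounds than this note shows. Statements on the series, on what has been measured and on what is new or still open speak of the compounds shown alone.

Measured compounds:
Compound 1, `Nc1ncnc2c1nc(NCc1cccc(Cl)c1)n2[C@@H]1O[C@H](CO)[C@@H](O)[C@H]1O`, gives 5400 nM in an assay on COS-7 cells for inhibition of sodium/nucleoside cotransporter 2 (Homo sapiens), read by scintillation counting, in the presence of a further agent that is not named here; on this read-out higher numbers stand for weaker inhibition and lower numbers for stronger inhibition.
Compound 2, `Nc1ncnc2c1nc(NCc1ccccc1-c1ccccc1)n2[C@@H]1O[C@H](CO)[C@@H](O)[C@H]1O`, gives > 100000 nM in this assay, a limit of the assay and not a number.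
Compound 3, `CCOC(=O)OC[C@H]1O[C@@H](n2cnc3c(N)ncnc32)[C@H](O)[C@@H]1O`, gives > 100000 nM in this assay, again a limit of the assay and not a number.

Compound 3 therefore stands among the weaker compounds shown: two of the three values sit at the same limit, as the limit of > 100000 nM in this assay, at which 2 of the 3 values shown sit, records, and only compound 1 gives a number at all. Among the measured compounds shown here, no step between measured compounds that differ in a single place is available, so nothing measured tells how a change of this kind moves the read-out.

Compound 4, `CNC(=O)OC[C@H]1O[C@@H](n2cnc3c(N)ncnc32)[C@H](O)[C@@H]1O`, differs from compound 3 by methylamino in place of ethoxy on a carbonyl carbon. The change is small and lies far from the shared core; the rest of the molecule is kept. With compound 3 already at the limit, the step of a number no higher from compound 3 to compound 4 (the limit leaves the size open) is expected to be none beyond the scatter, most likely another limit. Compound 4 is thus estimated at 100000 nM, with a range from 30000 nM to 300000 nM.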

Compound 4, half-maximal inhibitory concentration: > 100000 nM
Compound 4: only a limit was reported; the forecaster's own chance of this, stated with the estimate: 80%; the middle value lies on the limit itself.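

In this assay, among the compounds shown here, compound 3 and compound 4 both end at a limit of the assay and not at a number, so no step between them can be read: the limit of > 100000 nM in this assay, at which 3 of the 4 values shown sit.

As far as these compounds go, whether methylamino in place of ethoxy on a carbonyl carbon changes inhibition at all, and how far either compound lies beyond the limit, remains open.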